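Trifluoromethoxy replacing hydrogen on the sulfonamide-bearing ring

A few compounds are considered here, and "the series" means these few. Any claim that something is new, unique, unknown or untested is made for them only; others in the source may bear on it.

Measured compounds:
- compound 1, `CN(C)CC[C@H](CSc1ccccc1)Nc1ccc(S(=O)(=O)NC(=O)c2ccc(N3CCN(Cc4ccccc4-c4ccc(Cl)cc4)CC3)cc2)cc1C(F)(F)F`, in an assay on isolated protein for displacement of a labelled ligand from Bcl2-associated agonist of cell death (Homo sapiens), read by fluorescence polarization (on this read-out lower numbers stand for stronger inhibition and higher numbers for weaker inhibition), compound 1 gives < 1 nM, which is a limit of this assay.
- compound 2, `CN(C)CC[C@H](CSc1ccccc1)Nc1ccc(S(=O)(=O)NC(=O)c2ccc(N3CCN(Cc4ccccc4-c4ccc(Cl)cc4)CC3)cc2)cc1`, in this assay compound 2 gives 14 nM.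

Going by the values given here, compound 2 is the only compound with a definite number in this assay; compound 1 sits at the limit (the limit of < 1 nM in this assay, at which 1 of the 2 values shown sits). Among the compounds with values here, the single measured step, an at least 14-fold higher number from compound 1 to compound 2 (1.14 log units; beyond the scatter), is large and runs against removal of trifluoromethyl.

Compound 3, `CN(C)CC[C@H](CSc1ccccc1)Nc1ccc(S(=O)(=O)NC(=O)c2ccc(N3CCN(Cc4ccccc4-c4ccc(Cl)cc4)CC3)cc2)cc1OC(F)(F)F`, is not yet measured. It differs from compound 2 by trifluoromethoxy in place of hydrogen on an aromatic carbon. The same position changes as in the step from compound 1 to compound 2, and that step was large, so for compound 3 in this assay a large move toward lower numbers is expected, with a 9.3-fold lower number from compound 2 to compound 3 (0.97 log units; beyond the scatter). Compound 3 is therefore estimated at 1.5 nM, within 0.4 nM to 6 nM, with a real chance that only a limit is reported.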

Compound 3, inhibition constant: < 1 nM
Compound 3: only a limit was reported; the forecaster's own chance of this, stated with the estimate: 35%; at least 1.5-fold (0.17 log units) between middle value and limit.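

In this assay, trifluoromethoxy in place of hydrogen on this aromatic carbon, ortho to a large group and meta to a large group, gives an at least 14-fold lower number from compound 2 to compound 3 (1.14 log units; beyond the scatter). The large shift toward lower numbers at this position is therefore not confined to trifluoromethyl: two different groups, each compared with hydrogen on the shared core, take the series to the limit of the assay. The step between the two substituted compounds cannot be read, because both values are limits: the limit of < 1 nM in this assay, at which 2 of the 3 values shown sit.

Any difference between trifluoromethyl and trifluoromethoxy at this position remains open, as does the full size of each step from hydrogen. Also open, from the compounds shown here alone, is how a methyl, a methoxy, a chlorine, an amine or a carboxylic acid on this carbon would read out.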